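A few compounds are considered here, and "the series" means these few. Any claim that something is new, unique, unknown or untested is made for them only; others in the source may bear on it.

Of the compounds shown here, three have been measured in an assay for inhibition of steroid 17-alpha-hydroxylase/17,20 lyase (Homo sapiens), tested at 0.2 uM; on this read-out lower numbers stand for a weaker effect and higher numbers for a stronger effect at the one concentration tested. Compound 1, `Fc1ccc(-c2ccc3c(-c4ccncc4)cccc3c2)cc1`, gives 1% in this assay. Compound 2, `Fc1ccc(-c2ccc3c(Cn4ccnc4)cccc3c2)cc1`, carries the change (1H-imidazol-1-yl)methyl in place of pyridin-4-yl on an aromatic carbon relative to compound 1, and in this assay compound 2 gives 2%. The step of a number 1 percentage points higher from compound 1 to compound 2 (within the scatter) is within the scatter, so the two values cannot be told apart. Compound 3, `COc1ccc2cc(-c3cccc(-c4ccncc4)c3)ccc2c1`, is built on a different core from compound 1; the difference between the two cores is not broken down here. In this assay compound 3 gives 4%, a value that also lies within the scatter of the other two.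

Compound 4, `COc1ccc2cc(-c3cccc(Cn4ccnc4)c3)ccc2c1`, has not yet been measured. It stands to compound 3 as compound 2 stands to compound 1: the change is (1H-imidazol-1-yl)methyl in place of pyridin-4-yl on an aromatic carbon, the same kind of change as that between compound 1 and compound 2, though the surroundings differ. In compound 1 the group sits on an aromatic carbon of a six-membered aromatic ring of carbon only, part of a fused or bridged system of two rings, ortho to a fused ring and meta to a fused ring, whereas in compound 3 it sits on an aromatic carbon of a six-membered aromatic ring of carbon only, meta to a large group. Because a number 1 percentage points higher from compound 1 to compound 2 (within the scatter) lay within the scatter, the step is expected to be small as well, estimated at no change at the digits printed from compound 3 to compound 4 (within the scatter). Compound 4 is therefore expected to give about 4% in this assay, with a likely range from 0% to 14%.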

Compound 4, a percentage reported as inhibition, at one concentration (the size of the read-out at that concentration, not a potency): 0%
The estimate for compound 4 lay 4 percentage points above the measured number; low and high end bracket the measured number.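

In this assay, putting (1H-imidazol-1-yl)methyl in place of pyridin-4-yl on the core of compound 3 goes with a number 4 percentage points lower from compound 3 to compound 4 (within the scatter), and set beside the earlier step, the two cannot be told apart: the same change on two cores in this assay, a number 1 percentage points higher (within the scatter) from compound 1 to compound 2 and a number 4 percentage points lower (within the scatter) from compound 3 to compound 4, 5 percentage points apart, within the scatter of two such steps On these two cores, then, the change behaves alike only in the limited sense that neither step can be separated from the scatter, so the result from one core gave no reason to expect a different outcome on the other. This does not show that the change has no effect, or that it would transfer in the same way to a core with a clearly larger read-out, since the four compounds give values within a narrow range and each was read at one concentration, which gives no potency.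

The compounds shown leave open whether a different group on the same aromatic carbon, such as an amine, a carboxylic acid or a longer chain ending in an imidazole, would move the read-out beyond the scatter. They also leave open whether the pyridin-4-yl and (1H-imidazol-1-yl)methyl compounds would separate on a core other than these two.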